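Dichlorophenyl variant of the bis-benzylidene ketone series

The compounds below may be only part of what the source reports. "The series", "measured", "known", "first", "only" and "open" are said of these compounds alone.

The shared core is seen in compound 1 `COc1cccc(/C=C2\CCC/C(=C\c3cccc(Cl)c3)C2=O)c1OC`. In a functional assay on MCF7 cells (Homo sapiens) for cytotoxicity, read by MTT assay, with a stated time of 72 h (a lower number here means a stronger inhibitor, a higher number a weaker inhibitor), compound 1 gives 12000 nM, the highest of the two numbers recorded; compound 2 `COc1cccc(/C=C2\CCC/C(=C\c3cccc(OC)c3OC)C2=O)c1` gives 5900 nM, and the step of a 2.0-fold lower number from compound 1 to compound 2 (0.31 log units; beyond the scatter) is modest. Compound 3 `COc1cccc(/C=C2\CCC/C(=C\c3ccc(O)cc3)C2=O)c1OC` reaches only a limit, > 20000 nM (the limit of > 20000 nM in this assay, at which 1 of the 3 values shown sits). The step of an at least 1.6-fold higher number from compound 1 to compound 3 (0.22 log units; that floor lies within the scatter) stays within the scatter at its floor, while an at least 3.3-fold higher number from compound 2 to compound 3 (0.53 log units; beyond the scatter) is at least modest. Compound 4 `COc1cccc(/C=C2\CCC/C(=C\c3ccc(Cl)cc3Cl)C2=O)c1OC` differs from compound 1 by 2,4-dichlorophenyl in place of 3-chlorophenyl on a double-bonded chain carbon bound to a double-bonded ring carbon. Among the compounds with values here, no measured step exchanges one chlorophenyl for another, so the two steps from compound 1 give no direction; the expected outcome is a step of no size beyond the scatter, no change at the digits printed from compound 1 to compound 4 (within the scatter). Compound 4 is therefore estimated at 12000 nM, between 5000 nM and 30000 nM.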

Compound 4, half-maximal inhibitory concentration: > 20000 nM
Compound 4: only a limit was reported; the forecaster's own chance of this, stated with the estimate: 25%; middle value at least 1.6-fold (0.22 log units) away from the limit.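

In this assay compound 4 gives only a limit, the second compound in this set to do so: the limit of > 20000 nM in this assay, at which 2 of the 4 values shown sit. At this double-bonded chain carbon, the 2,4-dichlorophenyl group shows an at least 1.6-fold higher number from compound 1 to compound 4 (0.22 log units; that floor lies within the scatter), so no real loss against 3-chlorophenyl is established, while against 3-methoxyphenyl it shows an at least 3.3-fold higher number from compound 2 to compound 4 (0.53 log units; beyond the scatter). The step between compound 3 and compound 4 cannot be read, as both values are limits.

Still open, going by these compounds, is whether the second chlorine or the changed chlorine placement governs this step. Also open, on these data alone, is whether an aminophenyl group on this carbon would give a reading short of the limit.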